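This account rests on a few compounds, and the source may have more. Where it says the series, first, only, none or still open, it means among the compounds named here.

In a physicochemical assay for lipophilicity (a higher number here means a more lipophilic compound, a lower number a more polar compound), three compounds have been measured so far:
compound 1 `O=C1N=C(O)S/C1=C\c1ccc(OCC2CCCCO2)cc1` at 2.02
compound 2 `O=C1NC(=O)C(Cc2ccc(OCC3CCCCC3)cc2)S1` at 3.94
compound 3 `CCC(C)(C)Oc1ccc(/C=C2\SC(=O)NC2=O)cc1` at 3.49

Compound 2 stands highest of the three at 3.94 and lies above both others by more than the scatter. Compound 4 `CCCOc1ccc(CC2SC(=O)NC2=O)cc1` has not been measured yet. Its change from compound 2 is ethyl in place of cyclohexyl on a saturated chain carbon bound to an oxygen on an aromatic ring in one place, with ethyl in place of cyclohexyl on a saturated chain carbon bound to an oxygen on an aromatic ring. Going by the values given here, no measured pair shows this change, so the expectation rests on the structures alone. The expected step of a number 1.14 log units lower from compound 2 to compound 4 (beyond the scatter) is a clear fall beyond the scatter. Compound 4 is estimated at 2.8 with an expected range from 2.3 to 3.3 on this scale.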

Compound 4, partition coefficient: 2.96
For compound 4 the middle estimate is 0.16 log units below the measured one, within the range that was stated.
By their numbers in this assay, from the lowest: compound 1; then compound 4; then compound 3; then compound 2.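

In this assay, ethyl in place of cyclohexyl on a saturated chain carbon bound to an oxygen on an aromatic ring gives a number 0.98 log units lower from compound 2 to compound 4 (beyond the scatter). Going by these compounds alone, this is the first direct comparison at this position, and it shows that the reading responds to this change, here cyclohexylmethyl to propyl, with the rest of the molecule held the same. No supporting data explain the size of the step.

A single pair cannot separate losing the ring from losing carbons. Going by these compounds, what a hexyl chain, or a chain ending in an amine, would give at this place stays open.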